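Trimming the sulfur substituent on the 2-aminopurine riboside

The compounds below may be only part of what the source reports. "The series", "measured", "known", "first", "only" and "open" are said of these compounds alone.

Measured so far:
- compound 1 `CC(C)(Sc1ncnc2c1ncn2[C@@H]1O[C@H](CO)[C@@H](O)[C@H]1O)c1ccccc1`: in an assay on isolated protein for binding affinity to Equilibrative nucleoside transporter 1 (Homo sapiens) (a higher number here means a weaker inhibitor, a lower number a stronger inhibitor), compound 1 gives 21400 nM
- compound 2 `Cc1ccc(CSc2ncnc3c2ncn3[C@@H]2O[C@H](CO)[C@@H](O)[C@H]2O)cc1`: in this assay compound 2 gives 457 nM
- compound 3 `CCC(C)Sc1nc(N)nc2c1ncn2[C@@H]1O[C@H](CO)[C@@H](O)[C@H]1O`: in this assay compound 3 gives 63100 nM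

Compound 3 stands with the highest number of the three: compound 1 is its nearest neighbour, and compound 2 lies far below both. Compound 4 `CSc1nc(N)nc2c1ncn2[C@@H]1O[C@H](CO)[C@@H](O)[C@H]1O` differs from compound 3 by methyl in place of sec-butyl on a sulfur. For the measured compounds named here, the only measured step that touches the group on the sulfur is a 47-fold lower number from compound 1 to compound 2 (1.67 log units; beyond the scatter), a large change, but it exchanged groups on a different core and neither of them was a methyl, so it bears on the present step only loosely. On that basis the step from compound 3 to compound 4 is expected to lower the number, by a 5.3-fold lower number from compound 3 to compound 4 (0.72 log units; beyond the scatter), with wide uncertainty. Compound 4 is therefore estimated at 12000 nM, in a range from 2500 nM to 60000 nM.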

Compound 4, half-maximal inhibitory concentration: 204000 nM
Compound 4: middle estimate off by 17-fold (1.23 log units), on the low side; measured number above the stated range.
By their numbers in this assay, from the lowest: compound 2; then compound 1; then compound 3; then compound 4.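

Replacing sec-butyl with methyl on the sulfur gives a 3.2-fold higher number from compound 3 to compound 4 (0.51 log units; beyond the scatter) in this assay, so on this core the shorter group is the weaker of the two, and the size of the step is modest. The direction shows that the sec-butyl group gives a stronger inhibitor here than methyl does. No separate measurement bears on why the step runs this way.

On these data alone, what an ethyl group or a longer chain on the sulfur would give remains open. So does whether 4-methylbenzyl on the sulfur would give a stronger inhibitor on this core.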